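Series notes: from compound 3 to compound 4

A few compounds are considered here, and "the series" means these few. Any claim that something is new, unique, unknown or untested is made for them only; others in the source may bear on it.

Of the compounds shown here, three have been measured in an assay on BTI cells for inhibition of Amine oxidase [flavin-containing] B (Homo sapiens), read by fluorescence, with stated times of 30 min and 1 h, tested at 1 uM; on this read-out higher numbers stand for more inhibition at the one concentration tested (going by the name of the read-out) and lower numbers for less inhibition. Compound 1 `C#CCNC1CCc2c(OCCCCCN3CCN(c4cccc5c4ccn5Cc4cccc(Cl)c4)CC3)cccc21` gives 80%, and compound 2 `C#CCNC1CCc2c(OCCCCCCN3CCN(c4cccc5c4ccn5Cc4cccc(Cl)c4)CC3)cccc21` gives 34%. Among the compounds with values here, compound 3 `C[C@H](NCc1ccc(OCCCCCN2CCN(c3cccc4c3ccn4S(=O)(=O)c3ccccc3)CC2)cc1)C(N)=O`, the only member built on a different core, gives 17%; this is the lowest of the three numbers, beyond the scatter below compound 2 and further still below compound 1. Compound 4 `C#CCN(C)Cc1ccc(OCCCCCN2CCN(c3cccc4c3ccn4S(=O)(=O)c3ccccc3)CC2)cc1` has not yet been measured in this assay. It differs from compound 3 in one place: methyl(propargyl)amino in place of (1-carbamoylethyl)amino on a saturated chain carbon bound to an aromatic carbon.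

Within the data shown here, no step between measured compounds is available for this change, so the expectation rests on the values as they stand. Compound 1 and compound 2, which carry a propargylamino group of their own, give the two higher numbers, while compound 3 with its (1-carbamoylethyl)amino group gives the lowest. On that basis compound 4 is expected to gain, with an upward step of roughly a number 33 percentage points higher from compound 3 to compound 4 (beyond the scatter) in this assay. Compound 4 is estimated at 50%, within a range from 20% to 85%.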

Compound 4, a percentage reported as inhibition, at one concentration (the size of the read-out at that concentration, not a potency): 91%
Estimate against measurement, compound 4: 41 percentage points below, and the stated range ends below it.
By their numbers in this assay, from the lowest: compound 3; then compound 2; then compound 1; then compound 4.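

In this assay, methyl(propargyl)amino in place of (1-carbamoylethyl)amino on a saturated chain carbon bound to an aromatic carbon gives a number 74 percentage points higher from compound 3 to compound 4 (beyond the scatter). This place is therefore far from indifferent to the group it carries: with the rest of the structure unchanged, the low number of compound 3 belongs to its (1-carbamoylethyl)amino group and not to the core it shares with compound 4, which can reach high inhibition at the one concentration tested. Nothing measured here bears on why the step is so large.

The change removes the amide carbonyl and the defined stereocentre while adding the triple bond and the nitrogen methyl, so the compounds shown cannot say which of these differences carries the step. A dimethylamino group or a propargylamino group without the methyl at this place would begin to separate them.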